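The source may hold more compounds than are shown below. What is called first, only, known or untested is meant among the compounds shown, and "the series" means these compounds.

Measured so far:
Compound 1 `O=C(CCCCCCc1ccccc1)c1ncc(-c2ccc([N+](=O)[O-])cc2)o1` — in an assay (Rattus norvegicus) for inhibition of Fatty-acid amide hydrolase 1 (Homo sapiens) (a lower number here means a stronger inhibitor, a higher number a weaker inhibitor), compound 1 gives 50 nM.
Compound 2 `Nc1ccc(-c2cnc(C(=O)CCCCCCc3ccccc3)o2)cc1` — in this assay compound 2 gives 90 nM.

Among the measured compounds shown here, compound 2 stands at the higher of the two numbers seen in this assay, with compound 1 as its only neighbour; the step of a 1.8-fold higher number from compound 1 to compound 2 (0.26 log units; within the scatter) leaves the two within the scatter of each other, so no order between them can be claimed.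

Compound 3 `COC(=O)c1ccc(-c2cnc(C(=O)CCCCCCc3ccccc3)o2)cc1` has not yet been measured in this assay. It differs from compound 2 in one place: methoxycarbonyl in place of amino on an aromatic carbon. For the measured compounds named here, the only measured step that bears on this change is the one at the same place on the same ring, a 1.8-fold higher number from compound 1 to compound 2 (0.26 log units; within the scatter), where exchanging one group for another at that aromatic carbon moved the number by less than the scatter. On that single precedent, the exchange of amino for methoxycarbonyl is expected to produce no step beyond the scatter in this assay, in either direction, though one precedent is a thin basis.

Compound 3 is therefore expected to give about 80 nM in this assay, within a range from 30 nM to 250 nM, which corresponds to an estimated step of a 1.1-fold lower number from compound 2 to compound 3 (0.05 log units; within the scatter).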

Compound 3, inhibition constant: 40 nM
For compound 3 the middle estimate is 2.0-fold (0.30 log units) above the measured one; the range from low to high includes it.
By their numbers in this assay, from the lowest: compounds 3, 1 and 2 (each within the scatter of the next, the first and the last beyond it).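

In this assay, among the compounds shown here, the exchange of amino for methoxycarbonyl on this aromatic carbon, para to a large group, gives the first step at this position that lies beyond the scatter, a 2.3-fold lower number from compound 2 to compound 3 (0.35 log units; beyond the scatter), so the group carried here can move the number, though only modestly. The other new step, a 1.3-fold lower number from compound 1 to compound 3 (0.10 log units; within the scatter), stays within the scatter, as does a 1.8-fold higher number from compound 1 to compound 2 (0.26 log units; within the scatter), so nitro cannot be separated from either of the other two groups, and only compound 2 and compound 3 can be placed in an order. Nothing available explains why methoxycarbonyl and amino part in this way.

Going by these compounds, with three groups at this position, two of them separated only modestly and the third within the scatter of both, it remains open whether a carboxylic acid, a primary amide or a plain hydrogen on the same carbon would fall nearer compound 2 or compound 3. On these data alone, it is also open whether the same exchange would give a step of similar size if the phenyl-ended chain on the carbonyl were replaced by a shorter or longer chain.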